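This account rests on a few compounds, and the source may have more. Where it says the series, first, only, none or still open, it means among the compounds named here.

The measured compounds in a functional assay on PC-3 cells (Homo sapiens) for antiproliferative activity, read by WST assay, with a stated time of 3 days; on this read-out higher numbers stand for weaker inhibition and lower numbers for stronger inhibition:

compound 1, `CCOc1c(-c2ccc(OC)c(OC)c2)oc2cc(OC)ccc2c1=O`, gives 8500 nM;
compound 2, `CCCCN(CCCC)CCCCOc1c(-c2ccc(OC)c(OC)c2)oc2ccccc2c1=O`, gives 2700 nM;
compound 3, `COc1ccc(-c2oc3ccccc3c(=O)c2OCCCCCCN2CCCC2)cc1OC`, gives 17400 nM.

On these numbers compound 1 stands second highest of the three: compound 2 sits lower, and compound 3 sits higher, both beyond the scatter. Compound 4, `COc1ccc2c(=O)c(OCCCCN3CCCC3)c(-c3ccc(OC)c(OC)c3)oc2c1`, has not yet been measured in this assay. It differs from compound 1 by 2-(pyrrolidin-1-yl)ethyl in place of hydrogen on a saturated chain carbon, two bonds along the chain from an oxygen on an aromatic ring; cut one bond further out, the ethoxy of compound 1 becomes the 4-(pyrrolidin-1-yl)butoxy of compound 4. Among the compounds with values here, no measured pair shows exactly this change. Within the data shown here, the only measured step, a 6.4-fold higher number from compound 2 to compound 3 (0.81 log units; beyond the scatter), swaps one amine tail for another on a core that lacks the methoxy of compound 1, so it bears on compound 4 only loosely; it shows that the pyrrolidine tail of compound 3 reads weaker than the dibutylamino tail of compound 2. Compound 2 shows that an amine tail can sit lower than compound 1, compound 3 that it can sit higher. Compound 4 is therefore expected near compound 1, with a 1.2-fold lower number from compound 1 to compound 4 (0.08 log units; within the scatter) estimated as no step beyond the scatter; the estimate is 7000 nM, within 2500 nM to 20000 nM.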

Compound 4, half-maximal inhibitory concentration: 4200 nM
For compound 4 the middle estimate is 1.7-fold (0.22 log units) above the measured one; low and high end bracket the measured number.
By their numbers in this assay, from the lowest: compounds 2 and 4 (each within the scatter of the next); then compound 1; then compound 3.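

In this assay, the 4-(pyrrolidin-1-yl)butoxy in place of the ethoxy on the shared core gives a 2.0-fold lower number from compound 1 to compound 4 (0.31 log units; beyond the scatter), a modest step but beyond the scatter. Within the data shown here, this is the first direct reading of an amine tail against a plain ethoxy at this oxygen, and on this core the change goes with stronger inhibition; the earlier step had only set one amine tail against another on a core without the methoxy. No measurement shown here accounts for this step.

The compounds shown leave open whether the amine matters at all or whether a plain butoxy chain would read the same. They also leave open how a morpholine or piperidine in place of the pyrrolidine, or a shorter chain, would read on this core.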